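A few compounds are considered here, and "the series" means these few. Any claim that something is new, unique, unknown or untested is made for them only; others in the source may bear on it.

Compound 3 `COc1cccc(COc2cc(O)c3c(=O)c(O)c(-c4ccccc4)oc3c2)c1` stands at a limit in an ADME assay on Huh-5-2 cells (Homo sapiens) for cytotoxicity, read by WST assay, with a stated time of 3 days; a higher number here means that more compound is tolerated, a lower number that less compound is tolerated: the value recorded for compound 3, > 100000 nM, is an assay limit and not a number. Compound 1 `O=c1c(O)c(-c2ccccc2)oc2cc(OCc3ccccc3Cl)cc(O)c12` likewise gives only a limit, > 100000 nM. Compound 2 `O=c1c(O)c(-c2ccccc2)oc2cc(OCc3cccc(Br)c3)cc(O)c12` also gives only a limit, > 100000 nM. All values shown so far sit at the same ceiling (the limit of > 100000 nM in this assay, at which 3 of the 3 values shown sit). The step to compound 4 `O=c1c(O)c(-c2ccccc2)oc2cc(OCc3ccc(Br)cc3)cc(O)c12` is 4-bromophenyl in place of 3-methoxyphenyl on a saturated chain carbon bound to an oxygen on an aromatic ring. The measured steps that bear on it, a step that the two limits leave unreadable from compound 1 to compound 3, a step that the two limits leave unreadable from compound 2 to compound 3 and a step that the two limits leave unreadable from compound 1 to compound 2, are each unreadable between two limits, so no size can be drawn from any swap of the ring substituent. The step that the limit leaves unreadable from compound 3 to compound 4 is therefore expected to stay within the scatter, most likely again at the limit. Compound 4 is expected to give about 150000 nM, in a range from 60000 nM to 400000 nM.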

Compound 4, half-maximal cytotoxic concentration: > 100000 nM
Compound 4: a limit, no number; the forecaster's own chance of this, stated with the estimate: 85%; the middle value is on the limit's open side.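

In this assay, for the compounds shown here, no step among compound 1, compound 2, compound 3 and compound 4 can be read, as all four give only a limit: the limit of > 100000 nM in this assay, at which 4 of the 4 values shown sit. The compounds shown leave open whether these ring substituents differ at all in how much compound is tolerated.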